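Lengthening a Side Group Where Toxicity Stays Undetected

A few compounds are considered here, and "the series" means these few. Any claim that something is new, unique, unknown or untested is made for them only; others in the source may bear on it.

Compound 3, `CC(C)C[C@H](NC(=O)OC1CCC(F)(F)CC1)C(=O)N[C@@H](C[C@@H]1CCNC1=O)C(O)S(=O)(=O)O`, is one of three close relatives tested in a toxicity assay on Huh-7 cells (Homo sapiens) for cytotoxicity; a higher number here means that more compound is tolerated, a lower number that less compound is tolerated. In this assay compound 3 gives > 100000 nM, which is a limit of the assay rather than a number. Compound 1, `CC(C)C[C@H](NC(=O)OCC1CCC(F)(F)CC1)C(=O)N[C@H](C=O)C[C@@H]1CCNC1=O`, shows the same picture: in this assay compound 1 gives > 100000 nM, again a limit. Compound 2, `CCCC1CCC(OC(=O)N[C@@H](CC(C)C)C(=O)N[C@@H](C[C@@H]2CCNC2=O)C(O)S(=O)(=O)O)CC1`, in this assay gives > 100000 nM, also a limit. Compound 3 therefore stands exactly where every measured relative stands, at the limit of > 100000 nM in this assay, at which 3 of the 3 values shown sit.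

Compound 4, `CC(C)C[C@H](NC(=O)OCC1CCC(F)(F)CC1)C(=O)N[C@@H](C[C@@H]1CCNC1=O)C(O)S(=O)(=O)O`, has not yet been measured. It differs from compound 3 in one place: (4,4-difluorocyclohexyl)methyl in place of 4,4-difluorocyclohexyl on an oxygen next to a carbonyl group. Going by the values given here, the only measured step that touches the same position is a step that the two limits leave unreadable from compound 2 to compound 3; since both ends of that step are limits, its size cannot be read. Among the compounds with values here, no measured step tells how large an effect the change from compound 3 to compound 4 should have, so no direction can be read off either, and the evidence at the limit of > 100000 nM in this assay, at which 3 of the 3 values shown sit, for compounds 1, 2 and 3 suggests that the assay may once more report only a limit. For compound 4 the value is estimated at 150000 nM, with a range from 60000 nM to 400000 nM, which means an expected step that the limit leaves unreadable from compound 3 to compound 4.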

Compound 4, half-maximal cytotoxic concentration: > 100000 nM
Compound 4: only a limit was reported; the forecaster's own chance of this, stated with the estimate: 85%; the middle value is on the limit's open side.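

The steps from compound 1, compound 2 and compound 3 to compound 4 in this assay cannot be read, because all of these values are limits: the limit of > 100000 nM in this assay, at which 4 of the 4 values shown sit.

The compounds shown leave open at what concentration any of the four becomes toxic to these cells, and whether (4,4-difluorocyclohexyl)methyl and 4,4-difluorocyclohexyl differ at all in that respect.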